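From 3-fluorobenzyl to 3-chlorobenzyl: working notes

The compounds below may be only part of what the source reports. "The series", "measured", "known", "first", "only" and "open" are said of these compounds alone.

In a functional assay on HCT-116 cells (Homo sapiens) for cytotoxicity, read by MTT assay, with a stated time of 72 h (a lower number here means a stronger inhibitor, a higher number a weaker inhibitor), compound 1 (`Nc1ccccc1NC(=O)c1ccc(NC(=S)NCc2cccc(F)c2)cc1`) gives 5900 nM. Compound 2 (`Nc1ccccc1NC(=O)c1ccc(CNC(=O)c2cc3cnccc3[nH]2)cc1`) gives 4000 nM, and the two values lie within the scatter of each other. Compound 3 (`Nc1ccccc1NC(=O)c1ccc(NC(=S)NCc2cccc(Cl)c2)cc1`) has chloro in place of fluoro on an aromatic carbon, meta to a large group: chloro in place of fluoro on an aromatic carbon. Among the measured compounds shown here, no measured pair shows this change, so the expectation in this assay is for no shift beyond the scatter, with a slight lean towards a lower number. The estimated 1.3-fold lower number from compound 1 to compound 3 (0.12 log units; within the scatter) is small. Compound 3 is expected at 4500 nM, with an estimated range from 2000 nM to 10000 nM.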

Compound 3, half-maximal inhibitory concentration: 5900 nM
Beside the measured number, compound 3's estimate is 1.3-fold (0.12 log units) below it; low and high end bracket the measured number.
By their numbers in this assay, from the lowest: compounds 2, 1 and 3 (each within the scatter of the next).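

In this assay, among the compounds shown here, there is no change at the digits printed from compound 1 to compound 3 (within the scatter) and this is the first measured step at this position of the series. On this aromatic carbon, meta to a large group, chloro in place of fluoro therefore gives no shift beyond the scatter. No measurement is available to explain this result.

For the compounds shown here, only this one exchange is covered at this position. On these data alone, whether a methoxy, an amine or a carboxylic acid on this carbon reads the same stays open, as does whether chloro on another carbon of the ring does.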